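Amide variations on a shared core: notes toward compound 4

This account rests on a few compounds, and the source may have more. Where it says the series, first, only, none or still open, it means among the compounds named here.

Compound 1, `CC(C)n1ncc2c(C(=O)Nc3ccccc3)cccc21`: in a functional assay on MGC-803 cells (Homo sapiens) for inhibition, read by MTT assay, with a stated time of 72 h (a higher number here means a weaker inhibitor, a lower number a stronger inhibitor), compound 1 gives 38500 nM.
Compound 2, `CC(C)n1ncc2c(C(=O)NC3CCCC3)cccc21`: in this assay compound 2 gives > 40000 nM, a limit of the assay.
Compound 3, `CC(C)n1ncc2c(C(=O)NCc3cn(-c4cccc(F)c4)nn3)cccc21`: in this assay compound 3 gives > 40000 nM, a limit of the assay.

Compound 3 thus sits at the limit of > 40000 nM in this assay, at which 2 of the 3 values shown sit, with no number of its own. Going by the values given here, the only measured step, an at least 1.0-fold higher number from compound 1 to compound 2 (0.01 log units; that floor lies within the scatter), concerns the amide-type nitrogen and lies within the scatter; it does not touch the part altered here. Compound 4, `CC(C)n1ncc2c(C(=O)NCc3cn(Cc4ccccc4)nn3)cccc21`, differs from compound 3 by benzyl in place of 3-fluorophenyl on an aromatic nitrogen. Among the compounds with values here, no measured step bears on this change, so no move beyond the scatter is expected. Compound 4 is expected near 40000 nM, between 20000 nM and 80000 nM, most likely again as a limit. The expected step of a number no higher from compound 3 to compound 4 (the limit leaves the size open) is therefore essentially none.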

Compound 4, half-maximal inhibitory concentration: 14300 nM
Compound 4: the middle estimate sits 2.8-fold (0.45 log units) above what was measured; measured number below the stated range.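

In this assay, going by these compounds alone, benzyl in place of 3-fluorophenyl on the aromatic nitrogen gives an at least 2.7-fold lower number from compound 3 to compound 4 (0.44 log units; beyond the scatter), the first step beyond the scatter, so this position responds to change. Both groups hold the same count of heavy atoms and one six-membered aromatic ring of carbon only, so a swap of equal size by that count is enough to shift the read-out. The step remains a floor, since the value of compound 3 is only a limit: the limit of > 40000 nM in this assay, at which 2 of the 4 values shown sit.

From the compounds shown here alone, whether the step follows from the added carbon or the lost fluorine stays open, and a 3-fluorobenzyl group would separate the two. Going by these compounds, how a longer chain such as phenethyl behaves on this nitrogen also stays open.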